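The source may hold more compounds than are shown below. What is called first, only, known or untested is meant among the compounds shown, and "the series" means these compounds.

Measured so far:

- Compound 1, `O=C(Nc1ncc(Cc2ccc(F)cc2)s1)c1ccc(Br)cc1`: > 50000 nM
- Compound 2, `O=C(Nc1ncc(Cc2ccc(Br)cc2)s1)c1ccc2ccccc2c1`: > 50000 nM
- Compound 3, `Cc1cc(C(C)C)ccc1OC(c1ccc(Cl)cc1)c1cnc(NC(=O)OC(C)(C)C)s1`: > 50000 nM

All three compounds were tested in an ADME assay on HepG2 2.2.15 cells (Homo sapiens) for cytotoxicity; a higher number here means that more compound is tolerated, a lower number that less compound is tolerated. Compound 1 gives a value of > 50000 nM, which is a limit of the assay and not a number. Compound 2 likewise reaches only the limit of > 50000 nM. Compound 3 also sits at the limit, with > 50000 nM. Since every value shown is a limit, compound 3 cannot be placed above or below the others; all that can be said is that it tolerates compound up to the highest concentration tested, as described by the limit of > 50000 nM in this assay, at which 3 of the 3 values shown sit.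

Compound 4, `CC(C)(C)OC(=O)Nc1ncc(C(Oc2ccc(Br)cc2)c2ccc(Cl)cc2)s1`, has not yet been measured in this assay. It differs from compound 3 in one place: 4-bromophenyl in place of 4-isopropyl-2-methylphenyl on an oxygen on a saturated carbon. In words, a 4-bromophenyl takes the place of a 4-isopropyl-2-methylphenyl on an oxygen on a saturated carbon.

Among the measured compounds shown here, no measured step between any pair of compounds exists that would show how a change of this kind shifts the read-out. Because all three measured values sit at the limit given in the limit of > 50000 nM in this assay, at which 3 of the 3 values shown sit, the expectation is a step from compound 3 to compound 4 of a step that the limit leaves unreadable from compound 3 to compound 4, that is, none beyond the scatter. Compound 4 is therefore expected to give about 60000 nM, within a range from 25000 nM to 150000 nM, and most likely again only a limit.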

Compound 4, half-maximal cytotoxic concentration: > 50000 nM
Compound 4: no number, only a limit; the forecaster's own chance of this, stated with the estimate: 80%; the middle value is on the limit's open side.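

Compound 4 gives > 50000 nM in this assay, which is a limit of the assay and not a number. Compound 3 also has only a limit, so no step from compound 3 to compound 4 can be read: the limit of > 50000 nM in this assay, at which 4 of the 4 values shown sit.

The compounds shown leave open at what concentration any of them stops being tolerated, and whether 4-bromophenyl in place of 4-isopropyl-2-methylphenyl changes that concentration.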